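The source may report more compounds than this note shows. Statements on the series, on what has been measured and on what is new or still open speak of the compounds shown alone.

Measured compounds:
Compound 1 `Cc1ccc2nc(C(=O)Nc3c(F)cc(-c4cccc(F)c4)cc3F)c(C)c(O)c2c1` gives 56.4% in a functional assay on A-375 cells (Homo sapiens) for antiproliferative activity, read by MTT assay, with a stated time of 24 h, tested at 100 ug/mL; on this read-out higher numbers stand for a stronger effect at the one concentration tested and lower numbers for a weaker effect.
Compound 2 `Cc1c(C(=O)Nc2ccc(-c3ccccc3)cc2)nc2ccccc2c1O` gives 52.3% in this assay.
Compound 3 `Cc1ccc2nc(C(=O)Nc3c(F)cc(-c4cccc(F)c4)cc3F)c(C)c(C(=O)O)c2c1` gives 37.3% in this assay.

Among these three, compound 3 stands lowest; compound 2 is nearest to it and compound 1 furthest, both gaps lying beyond the scatter. Going by the values given here, the only single-point step among the measured compounds is a number 19.1 percentage points lower from compound 1 to compound 3 (beyond the scatter), which concerns a carboxy in place of a hydroxy and says nothing about substituents elsewhere on the core.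

Compound 4 `CCOc1ccc2nc(C(=O)Nc3c(F)cc(-c4cccc(F)c4)cc3F)c(C)c(C(=O)O)c2c1` differs from compound 3 in one place: ethoxy in place of methyl on an aromatic carbon. Among the compounds with values here, no measured step bears on an exchange of this kind, and compound 2, which carries neither group on its core, also differs from compound 3 in other respects, so its value offers no clean comparison. With nothing to point either way, the step of a number 0.3 percentage points lower from compound 3 to compound 4 (within the scatter) is expected to stay within the scatter. Compound 4 is therefore estimated at 37% in this assay, with a range from 22% to 52%.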

Compound 4, a percentage reported as inhibition, at one concentration (the size of the read-out at that concentration, not a potency): 72.4%
Compound 4: the middle estimate sits 35.4 percentage points below what was measured; the measured number lies above the stated range.
By their numbers in this assay, from the lowest: compound 3; then compounds 2 and 1 (each within the scatter of the next); then compound 4.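

In this assay, the aromatic carbon that is meta to a fused ring and para to a fused ring turns out to matter: ethoxy in place of methyl there gives a number 35.1 percentage points higher from compound 3 to compound 4 (beyond the scatter). Going by these compounds alone, the only earlier step, a number 19.1 percentage points lower from compound 1 to compound 3 (beyond the scatter), concerned a different place on the core and went down, whereas this change, made with the carboxy group in place, goes up, so the read-out also responds to the group at this second place. Nothing measured here explains the rise.

The compounds shown do not separate the part played by the ring-bound oxygen from that of the two-carbon chain, and what methoxy, propoxy, ethyl or an amine would give at this carbon stays open. Going by these compounds, it also remains open whether ethoxy would produce a similar step on the hydroxy-bearing compound 1.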